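Swapping a Fluoroindole for a Trifluorophenyl on a Shared Core

The source may hold more compounds than are shown below. What is called first, only, known or untested is meant among the compounds shown, and "the series" means these compounds.

Compound 1 `COc1ccc2c(OCc3nnc4sc(-c5cnn(C)c5)nn34)ccnc2c1`: 88 nM
Compound 2 `COc1ccc2c(OCc3nnc4sc(-c5cc6cc(F)ccc6[nH]5)nn34)ccnc2c1`: "not determined" (no result reported)
Compound 3 `COc1ccc2[nH]c(-c3nn4c(COc5ccnc6cc(OC)ccc56)nnc4s3)cc2c1`: 85.6 nM
Compound 4 `COc1ccc2c(OCc3nnc4sc(-c5cc(F)c(F)c(F)c5)nn34)ccnc2c1`: to be measured

On these data alone, in a functional assay on EBC-1 cells (Homo sapiens) for antiproliferative activity, with a stated time of 72 h (on this read-out lower numbers stand for stronger inhibition and higher numbers for weaker inhibition), compound 2 has no number at all, so its own standing is unknown. Compound 4 differs from it by 3,4,5-trifluorophenyl in place of 5-fluoro-1H-indol-2-yl on an aromatic carbon. Among the compounds with values here, the only measured step at this same position, a 1.0-fold lower number from compound 1 to compound 3 (0.01 log units; within the scatter), shows that exchanging one aromatic group for another there left the result essentially unchanged, and compound 1 and compound 3 sit close together. Within the data shown here, no step involves a fluorinated phenyl ring, so this is a guess by analogy: a group swap on this carbon is expected to move the number little if at all. Compound 4 is therefore estimated near 110 nM, with a range from 30 nM to 500 nM.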

Compound 4, half-maximal inhibitory concentration: 403 nM
Estimate against measurement, compound 4: 3.7-fold (0.56 log units) below, within the range that was stated.
By their numbers in this assay, from the lowest: compounds 3 and 1 (each within the scatter of the next); then compound 4.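

In this assay this carbon does not treat every aromatic group alike: 3,4,5-trifluorophenyl gives a 4.7-fold higher number from compound 3 to compound 4 (0.67 log units; beyond the scatter) and a 4.6-fold higher number from compound 1 to compound 4 (0.66 log units; beyond the scatter). Both steps lie beyond the scatter, unlike the earlier exchange of 1-methyl-1H-pyrazol-4-yl for 5-methoxy-1H-indol-2-yl. Compound 2 has no number, so any step from it cannot be read, and no measurement shown explains the higher number of compound 4.

A plain phenyl ring without fluorine is not among these compounds, so the part played by the three fluorines stays open. On these data alone, how a phenyl ring carrying an amine or a carboxylic acid would behave on this carbon is also open.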